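This account rests on a few compounds, and the source may have more. Where it says the series, first, only, none or still open, it means among the compounds named here.

Values in a functional assay on HL-60 cells (Homo sapiens) for cytotoxicity, read by XTT assay, with a stated time of 6 days (on this read-out lower numbers stand for stronger inhibition and higher numbers for weaker inhibition), for the measured compounds:

Compound 1 `CN(C)c1ncnc2[nH]cc(Sc3cccs3)c12` gives > 25000 nM (a limit of the assay, not a number)
Compound 2 `Nc1ncnc2[nH]cc(Sc3cccs3)c12` gives 13900 nM
Compound 3 `c1coc(-c2ncnc3[nH]cc(Sc4cccs4)c23)c1` gives 7630 nM

Within the data shown here, compound 3 and compound 2 hold the only two true numbers in this small set, and they cannot be ranked against each other. The comparison is a 1.8-fold lower number from compound 2 to compound 3 (0.26 log units; within the scatter) with furan-2-yl in place of amino. Against the limit of compound 1, the picture is an at least 3.2-fold lower number from compound 1 to compound 3 (0.51 log units; beyond the scatter) with furan-2-yl in place of dimethylamino.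

Compound 4 `Cc1ncnc2[nH]cc(Sc3cccs3)c12` keeps the shared core and carries methyl in place of furan-2-yl on an aromatic carbon at the same spot. Among the measured compounds shown here, no measured step brings in methyl, so only the two steps that exchange furan-2-yl at this carbon offer a guide. For the measured compounds named here, only the step involving compound 1 lies beyond the scatter, and read backwards it points to a higher number when furan-2-yl leaves. A small lean in that direction is therefore expected, with no clear move beyond the scatter. The expected change is a 1.6-fold higher number from compound 3 to compound 4 (0.20 log units; within the scatter) in this assay and remains an estimate. Compound 4 is estimated at 12000 nM with an expected range from 5000 nM to 25000 nM around that figure.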

Compound 4, half-maximal inhibitory concentration: > 25000 nM
Compound 4 ended at the assay's limit; the forecaster's own chance of this, stated with the estimate: 25%; middle value at least 2.0-fold (0.31 log units) away from the limit.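

In this assay, replacing furan-2-yl with methyl at this aromatic carbon gives an at least 3.2-fold higher number from compound 3 to compound 4 (0.51 log units; beyond the scatter), so this exchange now has a measured step beyond the scatter in which furan-2-yl leaves for a group with no ring. Replacing amino with methyl at the same carbon gives an at least 1.7-fold higher number from compound 2 to compound 4 (0.25 log units; that floor lies within the scatter), and that floor alone does not separate methyl from amino. The step between compound 1 and compound 4 cannot be read, so methyl and dimethylamino stay unranked, both ending at the same limit of the assay: the limit of > 25000 nM in this assay, at which 2 of the 4 values shown sit.

As far as these compounds go, compound 3 gives 7630 nM and compound 2 gives 13900 nM, two values within the scatter of each other, so the order of furan-2-yl and amino at this carbon stays open. The compounds shown also leave open whether another ring such as phenyl, or a longer chain such as propyl, would give a number like that of compound 3, and whether any group here could bring the number far lower.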